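The source may hold more compounds than are shown below. What is called first, only, known or untested is meant among the compounds shown, and "the series" means these compounds.

Going by the values given here, in a functional assay on NCI-H2228 cells (Homo sapiens) for inhibition, read by CellTiter-Glo, with a stated time of 96 h (a higher number here means a weaker inhibitor, a lower number a stronger inhibitor), the three compounds measured so far fall into two groups. Compound 1 `Cc1cc(Nc2ncc(Cl)c(Nc3cn(C)nc3S(=O)(=O)C(C)C)n2)c(OC2CC2)cc1C1COC1` gives 44 nM, and compound 3 `CC(C)S(=O)(=O)c1nn(C)cc1Nc1nc(Nc2ccc(C3CCN(C)CC3)cc2OC2CC2)ncc1Cl` gives 36 nM, values that sit within the usual scatter of each other. Compound 2 `Cc1cc(Nc2ncc(Cl)c(Nc3cn(C)nc3S(=O)(=O)C(C)C)n2)c(OC(C)C)cc1C1CCNC1` stands apart: in this assay compound 2 gives 364 nM, the highest number of the three, a higher number than compound 1 and a higher number than compound 3, both gaps beyond the scatter. Among the compounds with values here, no single-point step between measured compounds is available, since compound 2 differs from compound 1 and from compound 3 in more than one place. Which of those places matters for the gaps cannot be told from these values.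

Within the data shown here, compound 4 `Cc1cc(Nc2ncc(Cl)c(Nc3cn(C)nc3S(=O)(=O)C(C)C)n2)c(OC(C)C)cc1C1CNC1` is the first single-point neighbour of compound 2. It differs by azetidin-3-yl in place of pyrrolidin-3-yl on an aromatic carbon. Nothing measured so far isolates this change, so the direction rests on no shown step. Compound 4 is expected to move by a 1.5-fold lower number from compound 2 to compound 4 (0.16 log units; within the scatter), a step judged likely to lie within or only slightly beyond the scatter, in the direction of a lower number. On that basis compound 4 is estimated to give 250 nM in this assay, in a range from 90 nM to 700 nM.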

Compound 4, half-maximal inhibitory concentration: 288 nM
Compound 4: the middle estimate sits 1.2-fold (0.06 log units) below what was measured; the range from low to high includes it.
By their numbers in this assay, from the lowest: compounds 3 and 1 (each within the scatter of the next); then compounds 4 and 2 (each within the scatter of the next).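

In this assay, going by these compounds alone, the first comparison that isolates a single place shows that azetidin-3-yl in place of pyrrolidin-3-yl on an aromatic carbon gives a 1.3-fold lower number from compound 2 to compound 4 (0.10 log units; within the scatter), so compound 2 and compound 4 cannot be told apart at this position. The earlier compounds shown here could not show this, since each differed from the others in more than one place. Here the four-membered ring stands in for the five-membered ring, with one ring nitrogen and the same hydrogen-bond donor and acceptor counts in both groups, while the methyl group and the isopropoxy group on the same aromatic ring stay as they are, and no measured property bears on why the two values fall so close together.

The compounds shown leave open whether this position tolerates groups of another kind, such as an open-chain amine or a carboxylic acid, or a methyl group on the ring nitrogen of azetidin-3-yl with the isopropoxy group kept. They also leave open how the isopropoxy group alone, with everything else held fixed, would compare with other ethers at its place on the ring.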